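Five-membered aromatic swaps on the chlorophenyl arm

This account rests on a few compounds, and the source may have more. Where it says the series, first, only, none or still open, it means among the compounds named here.

Compound 1 `Cn1nc2c(=O)n(CC3(O)CCN(Cc4ccc(-c5ccncc5)cc4Cl)CC3)cnc2c1-c1ccc(CN)cc1` gives 257 nM in an assay on isolated protein for inhibition of ubiquitin carboxyl-terminal hydrolase 7 (Homo sapiens), with stated times of 30 min and 2 h; a higher number here means a weaker inhibitor, a lower number a stronger inhibitor.
Compound 2 `Cn1cc(-c2ccc(CN3CCC(O)(Cn4cnc5c(-c6ccc(CN)cc6)n(C)nc5c4=O)CC3)c(Cl)c2)cn1` gives 291 nM in this assay.
Compound 3 `Cn1nc2c(=O)n(CC3(O)CCN(Cc4ccc(-c5ccc[nH]5)cc4Cl)CC3)cnc2c1-c1ccc(CN)cc1` gives 193 nM in this assay.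

Compound 3 holds the lowest of the three numbers, yet its steps to the others stay within the scatter: a 1.3-fold lower number from compound 1 to compound 3 (0.12 log units; within the scatter) and a 1.5-fold lower number from compound 2 to compound 3 (0.18 log units; within the scatter). Compound 4 `Cn1nc2c(=O)n(CC3(O)CCN(Cc4ccc(-c5ncco5)cc4Cl)CC3)cnc2c1-c1ccc(CN)cc1` differs from compound 3 by 1,3-oxazol-2-yl in place of 1H-pyrrol-2-yl on an aromatic carbon. All measured steps exchange the group at this same position, including a 1.1-fold higher number from compound 1 to compound 2 (0.05 log units; within the scatter), and none moved the number beyond the scatter. The step to compound 4 is therefore expected to be small, a 1.1-fold higher number from compound 3 to compound 4 (0.06 log units; within the scatter), with no change beyond the scatter. Compound 4 is estimated at 220 nM, within a range from 110 nM to 450 nM.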

Compound 4, half-maximal inhibitory concentration: 1120 nM
For compound 4 the middle estimate is 5.1-fold (0.71 log units) below the measured one, outside the stated range (above it).
By their numbers in this assay, from the lowest: compounds 3, 1 and 2 (each within the scatter of the next); then compound 4.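

Among these compounds, the 1,3-oxazol-2-yl group brings the first steps beyond the scatter at this position in this assay: a 5.8-fold higher number from compound 3 to compound 4 (0.76 log units; beyond the scatter) and a 3.8-fold higher number from compound 2 to compound 4 (0.59 log units; beyond the scatter) and a 4.4-fold higher number from compound 1 to compound 4 (0.64 log units; beyond the scatter). So this position does respond to the group it carries, and a five-membered aromatic ring of 5 heavy atoms is not enough to hold the number, since 1H-pyrrol-2-yl and 1,3-oxazol-2-yl both fit that description. Nothing measured here accounts for the difference.

The compounds shown leave open whether the ring oxygen of the 1,3-oxazol-2-yl group or the loss of the hydrogen-bond donor of 1H-pyrrol-2-yl matters more. A 1,3-thiazol-2-yl or 1H-imidazol-2-yl group at this position would bear on that question.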